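A few compounds are considered here, and "the series" means these few. Any claim that something is new, unique, unknown or untested is made for them only; others in the source may bear on it.

Compound 1 `Cc1cc(O)c(C(=O)/C=C/c2ccccc2)c(-c2ccc(Br)cc2)c1C(=O)/C=C/c1ccccc1` is one of three close analogues on a shared core measured in a functional assay on HeLa cells (Homo sapiens) for cytotoxicity, read by MTT assay, with a stated time of 24 h; a higher number here means a weaker inhibitor, a lower number a stronger inhibitor. In that assay compound 1 gives 30000 nM, the higher of the two numbers reported. Compound 3 `Cc1cc(O)c(C(=O)/C=C/c2cccc(Cl)c2)c(-c2ccccc2)c1C(=O)/C=C/c1cccc(Cl)c1` gives 22000 nM, and the gap between compound 3 and compound 1 lies within the usual scatter of the measurement, so the two cannot be ordered. Compound 2 `COc1ccc(/C=C/C(=O)c2c(C)cc(O)c(C(=O)/C=C/c3ccc(OC)c(OC)c3)c2-c2ccccc2)cc1OC` is the third member; in this assay compound 2 is recorded as "not active" (no number reported), with no number attached. Compound 4 `Cc1cc(O)c(C(=O)/C=C/c2ccccc2)c(-c2ccccc2)c1C(=O)/C=C/c1ccccc1` has not yet been measured. It differs from compound 1 in one place: hydrogen in place of bromo on an aromatic carbon. For the measured compounds named here, no step between measured compounds isolates this change, so nothing in the data shows what hydrogen in place of bromo does here. Going by the values given here, the only comparison available, compound 1 against compound 3, shows two analogues within the scatter of each other, although compound 2, differently substituted, gave no number at all. For compound 4 the expectation is therefore a 1.2-fold higher number from compound 1 to compound 4 (0.07 log units; within the scatter), a step of no more than the scatter, with no clear direction. Compound 4 is accordingly estimated at 35000 nM, with a range from 12000 nM to 100000 nM.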

Compound 4, half-maximal inhibitory concentration: "not active" (no number reported)
Compound 4 has no reported number here, so the estimate cannot be set against anything.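

For the compounds shown here, compound 4 carries no number in this assay, so no step from compound 1 to compound 4 can be read. Nothing in the available data bears on this result. The compounds shown leave open what the change from 4-bromophenyl to phenyl does on its own to the read-out in this assay.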